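A Hydroxylated Ring in Place of an Ether Chain

The source may hold more compounds than are shown below. What is called first, only, known or untested is meant among the compounds shown, and "the series" means these compounds.

Compound 1, `COc1cc2cc(C#N)ccc2c(OC)c1Oc1cc(NCCCOC(C)C)nc(Nc2ccc(C#N)cc2)n1`, is tested in an ADME assay on MT4 cells (Homo sapiens) for cytotoxicity, read by MTT assay, with a stated time of 5 days; a higher number here means that more compound is tolerated, a lower number that less compound is tolerated. There compound 1 gives > 125000 nM, which is a limit of the assay rather than a measured number. Compound 2, `COc1cc2cc(C#N)ccc2c(OC)c1Oc1cc(NC2CCCC2)nc(Nc2ccc(C#N)cc2)n1`, gives > 125000 nM, again a limit and not a number. Compound 3, `COc1cc2cc(C#N)ccc2c(OC)c1Oc1cc(NCC(O)CO)nc(Nc2ccc(C#N)cc2)n1`, gives 29500 nM, a measured number. The step of an at least 4.2-fold lower number from compound 1 to compound 3 (0.62 log units; beyond the scatter) shows that a short chain carrying two hydroxyl groups, entering in place of an ether chain, lowers the tolerated concentration at least modestly; the step of an at least 4.2-fold lower number from compound 2 to compound 3 (0.62 log units; beyond the scatter) points the same way. The step that the two limits leave unreadable from compound 1 to compound 2 cannot be read, since both of its values sit at the limit of > 125000 nM in this assay, at which 2 of the 3 values shown sit.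

Compound 4, `COc1cc2cc(C#N)ccc2c(OC)c1Oc1cc(N2CCC(O)C2)nc(Nc2ccc(C#N)cc2)n1`, is not yet measured. It differs from compound 1 as follows: 3-hydroxypyrrolidin-1-yl in place of (3-isopropoxypropyl)amino on an aromatic carbon. The entering group brings one hydrogen-bond donor on a five-membered non-aromatic ring, where compound 3 carried two hydroxyl groups on an open chain. By analogy with compound 3 and its step of an at least 4.2-fold lower number from compound 1 to compound 3 (0.62 log units; beyond the scatter), a lower number than that of compound 1 is expected, but with a single hydroxyl the drop is expected to be smaller, giving an at least 1.7-fold lower number from compound 1 to compound 4 (0.25 log units; that floor lies within the scatter). Compound 4 is therefore estimated at 70000 nM, within a range from 25000 nM to 125000 nM.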

Compound 4, half-maximal cytotoxic concentration: > 125000 nM
Compound 4: only a limit was reported; the forecaster's own chance of this, stated with the estimate: 45%; middle value at least 1.7-fold (0.25 log units) from the limit.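

In this assay compound 4 gives > 125000 nM, which is a limit of the assay and not a number. Carrying a hydroxyl group at this position is therefore not enough on its own to lower the tolerated concentration, which the earlier compounds could not show: an at least 4.2-fold higher number from compound 3 to compound 4 (0.62 log units; beyond the scatter), with 3-hydroxypyrrolidin-1-yl replacing (2,3-dihydroxypropyl)amino, and compound 3 remains the only one of the four with a measured number. The steps to compound 4 from compound 1 and from compound 2 cannot be read, because both values in each pair sit at the same ceiling: the limit of > 125000 nM in this assay, at which 3 of the 4 values shown sit.

What separates compound 3 from compound 4 is still unresolved, since the two groups differ both in ring versus open chain and in their hydroxyl groups; a pyrrolidine ring carrying two hydroxyl groups, or an open hydroxyethyl chain, would help tell these apart. Going by these compounds, it also remains unknown how a charged group at this position, such as a carboxylic acid or a piperazine ring, would behave, and how far compounds 1, 2 and 4 lie beyond the limit.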